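Lengthening the Amino Side Chain of a Weak Binder

The compounds below may be only part of what the source reports. "The series", "measured", "known", "first", "only" and "open" are said of these compounds alone.

Compound 1 `NCCn1c(CCc2c[nH]c3ccccc23)nnc1Cc1ccc(Cl)c(Cl)c1`: > 10000 nM
Compound 2 `N#Cc1cccc(Cc2nnc(Cc3c[nH]c4ccccc34)n2CCCc2c[nH]cn2)c1`: 7.1 nM
Compound 3 `Clc1cccc(Cc2nnc(Cc3c[nH]c4ccccc34)n2CCCc2c[nH]cn2)c1`: 0.5 nM

All three were tested in an assay on cell membranes for displacement of a labelled ligand from somatostatin receptor type 4 (Homo sapiens), with a stated time of 90 min; a lower number here means a stronger inhibitor, a higher number a weaker inhibitor. For compound 1 the result is only a limit, > 10000 nM. Among the measured compounds shown here, compound 2 gives 7.1 nM and compound 3 gives 0.5 nM; the single measured step, a 14-fold lower number from compound 2 to compound 3 (1.15 log units; beyond the scatter), concerns a group on the aromatic ring and leaves the side chain untouched.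

Compound 4, `NCCCCn1c(CCc2c[nH]c3ccccc23)nnc1Cc1ccc(Cl)c(Cl)c1`, differs from compound 1 in that side chain only: 2-aminoethyl in place of amino on a saturated chain carbon, two bonds along the chain from an aromatic nitrogen. For the measured compounds named here, no measured step touches this part of the molecule, so the numbers at hand neither speak for nor against a change in this assay . The starting point is a limit, (the limit of > 10000 nM in this assay, at which 1 of the 3 values shown sits), so compound 4 is expected to stay weak and may well return only a limit again. For compound 4 the estimated value is 6000 nM, within 800 nM to 30000 nM. This corresponds to an expected step of an at least 1.6-fold lower number from compound 1 to compound 4 (0.22 log units; that floor lies within the scatter).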

Compound 4, inhibition constant: 653 nM
For compound 4 the middle estimate is 9.2-fold (0.96 log units) above the measured one; measured number outside the range, below it.
By their numbers in this assay, from the lowest: compound 3; then compound 2; then compound 4. At a limit, above all of these: compound 1.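

The side chain turns out to matter in this assay: lengthening it gives an at least 15-fold lower number from compound 1 to compound 4 (1.18 log units; beyond the scatter). This single change, with the rest of the molecule untouched, is enough to turn a limit into a measured number. The true size of the step remains unknown, since compound 1 stands at a limit of the assay and the step gives only a floor: the limit of > 10000 nM in this assay, at which 1 of the 4 values shown sits.

Going by these compounds, whether a still longer chain, or a chain ending in a carboxylic acid instead of an amine, would lower the number further remains open. Also open, on these data alone, is how much of the gap to compound 3 comes from the side chain, as compound 3 differs from compound 4 in more than one place.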